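Swapping the sulfur-bearing arm on the anilide of a shared core

The source may report more compounds than this note shows. Statements on the series, on what has been measured and on what is new or still open speak of the compounds shown alone.

Compound 1 `CCc1noc(C2CCN(c3ncnc(Nc4ccc(S(C)(=O)=O)cc4)c3[N+](=O)[O-])CC2)n1`: 10 nM
Compound 2 `CC(C)c1noc(C2CCN(c3ncnc(Nc4ccc(S(=O)(=O)C(C)C)cc4)c3[N+](=O)[O-])CC2)n1`: 7.8 nM
Compound 3 `CC[S+]([O-])c1ccc(Nc2ncnc(N3CCC(c4nc(C(C)C)no4)CC3)c2[N+](=O)[O-])cc1`: 17.1 nM

Of the compounds shown here, three built on one shared core have been measured in a functional assay for agonist activity at Glucose-dependent insulinotropic receptor (Homo sapiens); on this read-out lower numbers stand for an effect already at smaller amounts and higher numbers for an effect only at larger amounts of compound. Compound 3 stands at the highest number of the three; its value lies within the usual scatter of compound 1 and beyond it only against compound 2, where a 2.2-fold higher number from compound 2 to compound 3 (0.34 log units; beyond the scatter) was seen. That step replaced a group of six heavy atoms on an aromatic carbon with a group of four heavy atoms.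

Compound 4 `CCS(=O)(=O)c1ccc(Nc2ncnc(N3CCC(c4nc(C(C)C)no4)CC3)c2[N+](=O)[O-])c(F)c1` has not yet been measured. It differs from compound 3 by a group of 12 heavy atoms (8 carbon, 2 oxygen, 1 fluorine, 1 sulfur; one six-membered aromatic ring of carbon only) in place of a group of 10 heavy atoms (8 carbon, 1 oxygen, 1 sulfur; one six-membered aromatic ring of carbon only), on a nitrogen on an aromatic ring. The new arm brings two oxygens on sulfur, as in compound 1 and compound 2, and adds a fluorine. Going by the values given here, only the step from compound 2 to compound 3 bears on this, and it was modest; the fluorine has no measured counterpart here. Compound 4 is therefore expected to move back toward the numbers of compound 1 and compound 2, an expected 1.9-fold lower number from compound 3 to compound 4 (0.28 log units; within the scatter), giving an estimate of 9 nM with a range from 4 nM to 20 nM.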

Compound 4, half-maximal effective concentration: 7 nM
Compound 4: middle estimate off by 1.3-fold (0.11 log units), on the high side, and the stated range covers the measured number.
By their numbers in this assay, from the lowest: compounds 4, 2, 1 and 3 (each within the scatter of the next, the first and the last beyond it).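

In this assay, the arm on a nitrogen on an aromatic ring still responds to small edits: a 2.4-fold lower number from compound 3 to compound 4 (0.39 log units; beyond the scatter) comes with an arm carrying two oxygens on sulfur and a fluorine. Set against the arm with the isopropyl group on sulfur, a 1.1-fold lower number from compound 2 to compound 4 (0.05 log units; within the scatter) means that compound 2 and compound 4 cannot be told apart, so this arm, with its ethyl group and fluorine, is tolerated at least as well on the shared core. Nothing measured here explains the size of either step.

As far as these compounds go, compound 4 changes the oxygens on sulfur and adds the fluorine in one move, so the share of each remains unknown. From the compounds shown here alone, it is also open how the number would respond to a chlorine, a methoxy group or a nitrile in the place the fluorine holds in compound 4.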